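Shifting the methoxy group on the aryl substituent

The source may hold more compounds than are shown below. What is called first, only, known or untested is meant among the compounds shown, and "the series" means these compounds.

In a functional assay on MCF7 cells (Homo sapiens) for antiproliferative activity, read by MTT assay, with a stated time of 72 h (a higher number here means a weaker inhibitor, a lower number a stronger inhibitor), compound 1 `COc1cc(-n2cnc3ccc(-c4ccc(C)cc4F)cc32)cc(OC)c1OC` gives 56 nM and compound 2 `COc1ccc(-c2ccc3ncn(-c4cc(OC)c(OC)c(OC)c4)c3c2)cc1` gives 210 nM, so compound 2 holds the higher, weaker number of the two measured. The next change leads to compound 3 `COc1cccc(-c2ccc3ncn(-c4cc(OC)c(OC)c(OC)c4)c3c2)c1`: 3-methoxyphenyl in place of 4-methoxyphenyl on an aromatic carbon. Among the measured compounds shown here, only one measured step bears on this aromatic carbon, a 3.8-fold higher number from compound 1 to compound 2 (0.57 log units; beyond the scatter), a modest step that exchanges a differently substituted phenyl group. For the measured compounds named here, no measured pair isolates a shift of the methoxy group, so that step gives only a rough guide to size and none to direction. A smaller change is expected here, with nothing beyond the scatter in this assay. The estimated change is a 1.2-fold lower number from compound 2 to compound 3 (0.07 log units; within the scatter). For compound 3 the expected value is 180 nM, with an estimated range from 60 nM to 540 nM.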

Compound 3, half-maximal inhibitory concentration: 1610 nM
Compound 3: the middle estimate sits 8.9-fold (0.95 log units) below what was measured; measured number above the stated range.
By their numbers in this assay, from the lowest: compound 1; then compound 2; then compound 3.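

In this assay, moving the methoxy group with the atoms otherwise unchanged gives a 7.7-fold higher number from compound 2 to compound 3 (0.88 log units; beyond the scatter), so at this aromatic carbon the placement of the methoxy group on the phenyl ring matters, and not only the choice of phenyl substituent. The 3-methoxyphenyl group also falls well behind the 2-fluoro-4-methylphenyl group, with a 29-fold higher number from compound 1 to compound 3 (1.46 log units; beyond the scatter), which makes compound 3 the weakest of the three shown. Nothing available here accounts for this sensitivity to placement.

Compound 1 differs from the other two in both its fluoro and its methyl group, so the share of each in its lower number stays unresolved. Also open, on these data alone, is whether a hydroxyl group or an amine in place of the methoxy group would show the same dependence on placement.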